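The compounds below may be only part of what the source reports. "The series", "measured", "known", "first", "only" and "open" are said of these compounds alone.

Working notes on the series. All values come from a functional assay on UACC-62 cells (Homo sapiens) for inhibition, read by sulforhodamine B assay, with a stated time of 48 h; on this read-out lower numbers stand for stronger inhibition of growth and higher numbers for weaker inhibition of growth.

Compound 1, `C=C(C)[C@@H]1CC=C(Cn2cc(COc3ccc(C4NC(=O)NC(C)=C4C(C)=O)cc3)nn2)CC1`: 20500 nM
Compound 2, `C=C(C)[C@@H]1CC=C(Cn2cc(COc3ccc(C4NC(=O)NC(C)=C4C(C)=O)cc3OC)nn2)CC1`: 3830 nM
Compound 3, `C=C(C)[C@@H]1CC=C(Cn2cc(COc3cccc(C4NC(=O)NC5=C4C(=O)CC(C)(C)C5)c3)nn2)CC1`: 20900 nM

Compound 2 differs from compound 1 by methoxy in place of hydrogen on an aromatic carbon, and this change gave a 5.4-fold lower number from compound 1 to compound 2 (0.73 log units; beyond the scatter). Compound 3 carries a different core from compound 1; the difference between the two cores is not broken down here. In this assay compound 3 and compound 1 lie within the scatter of each other, so no order between them is claimed.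

Compound 4, `C=C(C)[C@@H]1CC=C(Cn2cc(COc3cc(C4NC(=O)NC5=C4C(=O)CC(C)(C)C5)ccc3OC)nn2)CC1`, is not yet measured. It differs from compound 3 by methoxy in place of hydrogen on an aromatic carbon. Going by the values given here, this is the same kind of change as the one from compound 1 to compound 2, though not the same: in compound 2 the methoxy stands ortho to a large group and meta to a large group, whereas in compound 4 it stands ortho to a large group and para to a large group, and it sits on the other core. Among the compounds with values here, only one measured example of this change exists. Resting on a 5.4-fold lower number from compound 1 to compound 2 (0.73 log units; beyond the scatter) and allowing for the differing place and core, the expected step is a 3.0-fold lower number from compound 3 to compound 4 (0.48 log units; beyond the scatter). Compound 4 is expected to give 7000 nM in this assay, within an expected range from 2500 nM to 18000 nM.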

Compound 4, concentration for total growth inhibition: 62000 nM
Beside the measured number, compound 4's estimate is 8.9-fold (0.95 log units) below it; the whole stated range lies below it.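

In this assay, methoxy in place of hydrogen on an aromatic carbon does not carry over from one core to the other; on the core of compound 3 it gives a 3.0-fold higher number from compound 3 to compound 4 (0.47 log units; beyond the scatter), and the two steps run in opposite directions and differ: the same change on two cores in this assay, a 5.4-fold lower number (0.73 log units; beyond the scatter) from compound 1 to compound 2 and a 3.0-fold higher number (0.47 log units; beyond the scatter) from compound 3 to compound 4, 16-fold (1.20 log units) apart, beyond the scatter of two such steps

The two pairs differ both in core and in the place of the methoxy, which in compound 4 stands ortho to a large group and para to a large group, so the difference cannot be assigned to the core alone or to the place alone. With a single step on each core, the data give no rule for either core and no explanation for the reversal.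

On these data alone, it remains open whether methoxy at one identical place on both cores would give steps of the same direction. As far as these compounds go, it is also open how the two cores would respond to another group at these places, such as hydroxy, ethoxy, chloro or an amine.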